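The source may report more compounds than this note shows. Statements on the series, on what has been measured and on what is new or still open speak of the compounds shown alone.

Working notes on the series. Compound 1 `CCCCCCCCCCn1cc(Cn2c(CC)nc3nc(-c4ccccc4)cc(C(F)(F)F)c3c2=O)nn1` was tested in a functional assay on COLO 205 cells (Homo sapiens) for cytotoxicity, read by MTT assay, with a stated time of 24 h (on this read-out lower numbers stand for stronger inhibition and higher numbers for weaker inhibition), and gives only a limit of the assay, > 200 ug/mL. Compound 2 `Cc1nc(OCc2cn(CCC(F)(F)C(F)(F)C(F)(F)C(F)(F)C(F)(F)C(F)(F)C(F)(F)C(F)(F)F)nn2)c2c(C(F)(F)F)cc(-c3ccccc3)nc2n1` likewise gives only a limit in this assay, namely > 200 ug/mL. Among the measured compounds shown here, compound 2 thus stands where every measured value so far sits, at the limit of > 200 ug/mL in this assay, at which 2 of the 2 values shown sit. The next compound, compound 3 `FC(F)(F)c1cc(-c2ccccc2)nc2nc(-c3ccccc3)nc(OCc3cn(CCC(F)(F)C(F)(F)C(F)(F)C(F)(F)C(F)(F)C(F)(F)C(F)(F)C(F)(F)F)nn3)c12`, differs from compound 2 by phenyl in place of methyl on an aromatic carbon. For the measured compounds named here, no measured pair shows a step of this kind, so nothing beyond the scatter is expected in this assay. Compound 3 is therefore expected to give about 200 ug/mL, within 100 ug/mL to 400 ug/mL, most probably again as a limit. The expected step is a number no higher from compound 2 to compound 3 (the limit leaves the size open).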

Compound 3, half-maximal inhibitory concentration: > 200 ug/mL
Compound 3: only a limit was reported (the forecaster's own chance of this, stated with the estimate: 80%); the middle value lies on the limit itself.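

Compound 2 and compound 3 both give only a limit, so no step can be read for phenyl in place of methyl on an aromatic carbon. The compounds shown leave open whether any change to the shared core gives a measurable value in this assay.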